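A few compounds are considered here, and "the series" means these few. Any claim that something is new, unique, unknown or untested is made for them only; others in the source may bear on it.

Compound 1, `CC(C)Nc1sc(C(=O)c2ccc(Cl)s2)c(N)c1C#N`, gives 192 nM in an assay for inhibition of Maternal embryonic leucine zipper kinase (Homo sapiens), read by ADP-Glo, with a stated time of 0.5 h; a higher number here means a weaker inhibitor, a lower number a stronger inhibitor.
Compound 2, `CC(C)Nc1sc(C(=O)c2ccc(Br)s2)c(N)c1C#N`, gives 122 nM in this assay.

In this assay, going by the values given here, compound 1 holds the higher of the two numbers, yet its only neighbour is close: the step of a 1.6-fold lower number from compound 1 to compound 2 (0.20 log units; within the scatter) amounts to bromo in place of chloro on an aromatic carbon and does not separate the two compounds beyond the usual scatter.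

Compound 3, `CC(C)N(C)c1sc(C(=O)c2ccc(Cl)s2)c(N)c1C#N`, has not yet been measured in this assay. It differs from compound 1 by methyl in place of hydrogen on a nitrogen on an aromatic ring; read one bond further out, the change is isopropylamino to isopropyl(methyl)amino. Among the compounds with values here, the single measured step concerns the halogen on the other ring and says nothing about a methyl on this nitrogen, so there is no measured step that bears on the change from compound 1 to compound 3.

With no guide from the data, compound 3 is expected to land somewhat above compound 1, with a wide range on either side, that is an estimated step of a 3.1-fold higher number from compound 1 to compound 3 (0.49 log units; beyond the scatter) in this assay. The estimate for compound 3 is 600 nM, between 120 nM and 3000 nM.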

Compound 3, half-maximal inhibitory concentration: 1420 nM
Compound 3: the middle estimate sits 2.4-fold (0.37 log units) below what was measured, within the range that was stated.
By their numbers in this assay, from the lowest: compounds 2 and 1 (each within the scatter of the next); then compound 3.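

Adding methyl to this nitrogen weakens inhibition in this assay: the change from isopropylamino to isopropyl(methyl)amino gives a 7.4-fold higher number from compound 1 to compound 3 (0.87 log units; beyond the scatter) and is the first step here to lie beyond the scatter. Going by these compounds alone, the halogen change, by contrast, gave only a 1.6-fold lower number from compound 1 to compound 2 (0.20 log units; within the scatter) and did not separate its two compounds, so the nitrogen on the aromatic ring is the first place in these compounds where a small change, a single heavy atom replacing a hydrogen, clearly moves the number. No accompanying measurement accounts for this step, and its origin remains unexplained.

The compounds shown leave open whether a longer chain such as ethyl on this nitrogen would raise the number as methyl does, and whether the isopropyl itself could give way to a cyclopropyl or a hydroxyethyl chain while the hydrogen stays in place. They also leave open whether methyl on the nitrogen of compound 2 would give a step of similar size, and how a methoxy group or a nitrile would read in place of the halogen.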